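The compounds below may be only part of what the source reports. "The series", "measured", "known", "first", "only" and "open" are said of these compounds alone.

Compound 1 `COC(=O)c1[nH]c2ccc(Cl)cc2c1C(=O)c1cc(OC)c(OC)c(OC)c1N` gives 2140 nM in a functional assay on HT-29 cells (Homo sapiens) for cytotoxicity, read by sulforhodamine B assay, with a stated time of 48 h; on this read-out lower numbers stand for stronger inhibition of growth and higher numbers for weaker inhibition of growth.
Compound 2 `COc1cc(Cc2c[nH]c3ccccc23)c(N)c(OC)c1OC` reaches only the limit > 100000 nM in this assay.
Compound 3 `COc1ccc2c(Cc3cc(OC)c(OC)c(OC)c3N)c[nH]c2c1` gives 74800 nM in this assay.

Compound 3 carries the highest of the two numbers recorded; compound 1 sits far lower, beyond the scatter. The entry for compound 2 is the limit of > 100000 nM in this assay, at which 1 of the 3 values shown sits. Compound 4 `COc1cc2[nH]cc(Cc3cc(OC)c(OC)c(OC)c3N)c2cc1OC` differs from compound 3 by methoxy in place of hydrogen on an aromatic carbon. Among the compounds with values here, only one measured step resembles this change, namely an at least 1.3-fold lower number from compound 2 to compound 3 (0.12 log units; that floor lies within the scatter), and that step could not be separated from the scatter, since one of its ends is a limit. Within the data shown here, no measured step therefore points to a change beyond the scatter in this assay for adding a further methoxy here, and the estimated step is a 1.4-fold lower number from compound 3 to compound 4 (0.13 log units; within the scatter), which is expected to lie within the usual spread. Compound 4 is accordingly expected to give 55000 nM in this assay, with a likely range from 15000 nM to 150000 nM, and with a fair chance that only a limit is reported.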

Compound 4, concentration for 50% growth inhibition: "not active" (no number reported)
Compound 4 has no reported number here, so the estimate cannot be set against anything.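

Within the data shown here, compound 4 is recorded as not active, without a number, so no step from compound 3 to compound 4 can be read in this assay. The compounds shown leave open whether methoxy in place of hydrogen on an aromatic carbon changes growth inhibition at all, since the only comparable step starts from compound 2, which stands at a limit: the limit of > 100000 nM in this assay, at which 1 of the 4 values shown sits.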